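The source may report more compounds than this note shows. Statements on the series, on what has been measured and on what is new or still open speak of the compounds shown alone.

Measured compounds:
Compound 1 `Cc1ccc2occ([C@@H]3C[C@H](c4ccccc4)ON3c3ccccc3)c(=O)c2c1` gives > 60000 nM in a functional assay on THP-1 cells (Homo sapiens) for inhibition, read by sulforhodamine B assay, with a stated time of 48 h (on this read-out higher numbers stand for weaker inhibition and lower numbers for stronger inhibition), which is a limit of the assay and not a number.
Compound 2 `Cc1ccc2occ([C@@H]3[C@H]4C(=O)N(c5ccccc5)C(=O)[C@H]4ON3c3ccccc3)c(=O)c2c1` gives > 60000 nM in this assay, again a limit.
Compound 3 `O=c1c([C@@H]2C[C@H](c3ccccc3)ON2c2ccccc2)coc2ccccc12` gives > 60000 nM in this assay, also a limit.

All three measured compounds thus sit at the limit of > 60000 nM in this assay, at which 3 of the 3 values shown sit, and compound 2 is known only by that limit, with no number attached. For the measured compounds named here, the one measured pair that differs in a single place, hydrogen in place of methyl on an aromatic carbon, gives a step that the two limits leave unreadable from compound 1 to compound 3, so nothing about the size or direction of a change at that position can be read from it.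

Compound 4 `O=C1[C@H]2[C@H](ON(c3ccccc3)[C@@H]2c2coc3ccc(Br)cc3c2=O)C(=O)N1c1ccccc1` is the compound still to be measured. It differs from compound 2 by bromo in place of methyl on an aromatic carbon. Going by the values given here, no measured step bears on this change in a readable way, since every value so far is a limit. The expectation for the step that the limit leaves unreadable from compound 2 to compound 4 is therefore that compound 4 most likely also comes back as a limit. Compound 4 is estimated at 80000 nM, in a range from 20000 nM to 300000 nM.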

Compound 4, half-maximal inhibitory concentration: 22300 nM
Estimate against measurement, compound 4: 3.6-fold (0.55 log units) above; the range from low to high includes it.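

With bromo in place of methyl on this aromatic carbon, the series gives its first readable step, an at least 2.6-fold lower number from compound 2 to compound 4 (0.42 log units; beyond the scatter), in this assay. That step is only a minimum, as its starting point, compound 2, has a limit and not a number. It shows that a change at this position can move the read-out, something the earlier compounds could not show, as the other steps remain unreadable and every other value is a limit: the limit of > 60000 nM in this assay, at which 3 of the 4 values shown sit.

It remains open whether this shift is particular to bromo, as chloro, methoxy or an amine on the same carbon are not among the compounds shown. On these data alone, it is also open whether bromo would bring a similar change on the core of compound 1, which carries the same methyl group.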